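Swapping the aryl group on a cytotoxic series

The source may report more compounds than this note shows. Statements on the series, on what has been measured and on what is new or still open speak of the compounds shown alone.

Measured so far in a functional assay on PC-3 cells (Homo sapiens) for cytotoxicity, read by MTT assay, with a stated time of 72 h; a higher number here means a weaker inhibitor, a lower number a stronger inhibitor
Compound 1 `COc1cc(/C=N/NC(=O)Nc2cc3c(Nc4ccc(F)c(Cl)c4)ncnc3cc2O[C@H]2CCOC2)cc(OC)c1OC` gives 29600 nM
Compound 2 `COc1cc2ncnc(Nc3ccc(F)c(Cl)c3)c2cc1NC(=O)N/N=C/c1cccc(Br)c1` gives "not active" (no number reported)
Compound 3 `COc1cc2ncnc(Nc3ccc(F)c(Cl)c3)c2cc1NC(=O)N/N=C/c1ccc(F)cc1Cl` gives 25700 nM

Compound 3 at 25700 nM and compound 1 at 29600 nM lie within the usual scatter of each other, so these two numbers cannot be told apart. Compound 2 was reported as "not active" (no number reported) and has no number to compare.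

Compound 4 `COc1cc2ncnc(Nc3ccc(F)c(Cl)c3)c2cc1NC(=O)N/N=C/c1cc(OC)c(OC)c(OC)c1` has not yet been measured. It differs from compound 3 at one place (3,4,5-trimethoxyphenyl in place of 2-chloro-4-fluorophenyl on a carbon with a double bond to nitrogen), where 3,4,5-trimethoxyphenyl stands in place of 2-chloro-4-fluorophenyl on a carbon with a double bond to nitrogen.

Among the measured compounds shown here, no measured pair shows this exchange on its own, so any forecast is uncertain. The entering group does appear in compound 1, which gives 29600 nM in this assay and sits close to compound 3. On that ground, no step beyond the scatter is expected, in either direction. Compound 2 at "not active" (no number reported) is a reminder that a result without a number is also possible.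

The estimated change is a 1.1-fold higher number from compound 3 to compound 4 (0.04 log units; within the scatter) and would be a small one. Compound 4 is expected at 28000 nM with an estimated range from 12000 nM to 60000 nM as its likely span.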

Compound 4, half-maximal inhibitory concentration: 36500 nM
The estimate for compound 4 lay 1.3-fold (0.12 log units) below the measured number, within the range that was stated.
By their numbers in this assay, from the lowest: compounds 3, 1 and 4 (each within the scatter of the next).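

In this assay, the exchange of 2-chloro-4-fluorophenyl for 3,4,5-trimethoxyphenyl on a carbon with a double bond to nitrogen can now be read directly, and it gives a 1.4-fold higher number from compound 3 to compound 4 (0.15 log units; within the scatter) even though the entering group has hydrogen-bond acceptors and the leaving group has none. The new compound also opens a second comparison with 3,4,5-trimethoxyphenyl held fixed, where methyl in place of oxolan-3-yl on an oxygen on an aromatic ring gives a 1.2-fold higher number from compound 1 to compound 4 (0.09 log units; within the scatter) and so also stays within the usual scatter of repeated measurements. Neither change therefore separates these compounds by number, and no measurement shown here offers an explanation for either result.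

Among the compounds shown here, compound 2 has no number, so the 3-bromophenyl variant cannot be placed on the same scale, and the compounds with numbers show no step large enough to reveal what this position can tolerate. From the compounds shown here alone, it remains open whether an aryl group carrying an amine or a carboxylic acid at the carbon with a double bond to nitrogen, or a longer chain in place of methyl on the oxygen, would move the number beyond the scatter.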